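Drawing the other configuration at the chain centre of compound 2

A few compounds are considered here, and "the series" means these few. Any claim that something is new, unique, unknown or untested is made for them only; others in the source may bear on it.

Measured so far:
compound 1 `COC(=O)c1cc(CC(C)CN2C[C@@H]3CCCC[C@@H]3[C@H](C(=O)N3CCN(c4ccc([N+](=O)[O-])cc4)CC3)C2)cc(C(=O)OC)c1` with 1.35 nM
compound 2 `COC(=O)c1cc(C[C@@H](C)CN2C[C@@H]3CCCC[C@@H]3[C@H](C(=O)N3CCN(c4ccc([N+](=O)[O-])cc4)CC3)C2)cc(C(=O)OC)c1` with 2.24 nM

In an assay on isolated protein for binding affinity to somatostatin receptor type 3 (Homo sapiens) (on this read-out lower numbers stand for tighter binding and higher numbers for weaker binding), compound 1 gives 1.35 nM and compound 2 gives 2.24 nM. Within the data shown here, compound 2 stands alongside compound 1, the only other measured compound, with a 1.7-fold higher number from compound 1 to compound 2 (0.22 log units; within the scatter), a step that rests on (the fact that one of compounds 1 and 2 is drawn with a defined configuration and the other without, at the place where they differ). Compound 3 `COC(=O)c1cc(C[C@H](C)CN2C[C@@H]3CCCC[C@@H]3[C@H](C(=O)N3CCN(c4ccc([N+](=O)[O-])cc4)CC3)C2)cc(C(=O)OC)c1` differs from compound 2 in this way: the two compounds have the same atoms and bonds and differ only in configuration as drawn: 1 of 4 stereo elements differ; a stereocentre at a saturated chain carbon is drawn R in compound 2 and S in compound 3. Among the measured compounds shown here, the only step that bears on it is a 1.7-fold higher number from compound 1 to compound 2 (0.22 log units; within the scatter); since compound 1 carries no drawn configuration at that centre, a step of similar size in the opposite direction, or none beyond the scatter, is expected. Compound 3 is therefore estimated at 1 nM, with a range from 0.4 nM to 2.5 nM, which means an expected 2.2-fold lower number from compound 2 to compound 3 (0.35 log units; beyond the scatter).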

Compound 3, dissociation constant: 1.23 nM
Beside the measured number, compound 3's estimate is 1.2-fold (0.09 log units) below it; low and high end bracket the measured number.
By their numbers in this assay, from the lowest: compounds 3, 1 and 2 (each within the scatter of the next).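

In this assay, the R and S drawings at the chain centre can now be compared directly, and the result is a 1.8-fold lower number from compound 2 to compound 3 (0.26 log units; within the scatter). Against the drawing without a configuration, the S drawing gives a 1.1-fold lower number from compound 1 to compound 3 (0.04 log units; within the scatter). Neither step exceeds the scatter, so these three compounds show no measurable preference for either configuration at this centre.

Still open, going by these compounds, is what an ethyl group in place of the methyl group at this centre, or an unbranched chain, would do to the number. Also open, on these data alone, is whether the stereocentres of the shared core tolerate inversion equally well.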